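The compounds below may be only part of what the source reports. "The series", "measured", "known", "first", "only" and "open" are said of these compounds alone.

In a functional assay on MKN-45 cells (Homo sapiens) for antiproliferative activity, read by MTT assay, with a stated time of 72 h, tested at 10 uM (a lower number here means less inhibition, a higher number more inhibition at the concentration tested (going by the name of the read-out)), compound 3 `O=C(CO)Nc1cc(Oc2ccc(Nc3nccc4[nH]cc(-c5ccc(F)cc5)c(=O)c34)cc2F)ccn1` gives 63%, the lowest of the three measured numbers. Compound 1 `CCC(=O)Nc1cc(Oc2ccc(Nc3nccc4[nH]cc(-c5ccc(F)cc5)c(=O)c34)cc2F)ccn1` gives 92.1% and compound 2 `CC(C)C(=O)Nc1cc(Oc2ccc(Nc3nccc4[nH]cc(-c5ccc(F)cc5)c(=O)c34)cc2F)ccn1` gives 95.4%, and these two lie within the scatter of each other, as the step of a number 3.3 percentage points higher from compound 1 to compound 2 (within the scatter) shows. Compound 4 `O=C(Nc1cc(Oc2ccc(Nc3nccc4[nH]cc(-c5ccc(F)cc5)c(=O)c34)cc2F)ccn1)C1CCC1` differs from compound 3 by cyclobutyl in place of hydroxymethyl on a carbonyl carbon. Among the compounds with values here, the steps that bear on this change are a number 32.4 percentage points lower from compound 2 to compound 3 (beyond the scatter) and a number 29.1 percentage points lower from compound 1 to compound 3 (beyond the scatter), both of which set compound 3 well beneath the other two. Compound 4 carries cyclobutyl on the carbonyl carbon, much as compound 2 carries isopropyl there. For compound 4 a gain of similar size is therefore expected, about a number 29 percentage points higher from compound 3 to compound 4 (beyond the scatter). Compound 4 is estimated at 92%, between 82% and 98%.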

Compound 4, a percentage reported as inhibition, at one concentration (the size of the read-out at that concentration, not a potency): 52.8%
Compound 4: middle estimate off by 39.2 percentage points, on the high side; the measured number lies below the stated range.
By their numbers in this assay, from the lowest: compound 4; then compound 3; then compounds 1 and 2 (each within the scatter of the next).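

Cyclobutyl in place of isopropyl gives a number 42.6 percentage points lower from compound 2 to compound 4 (beyond the scatter) and cyclobutyl in place of ethyl gives a number 39.3 percentage points lower from compound 1 to compound 4 (beyond the scatter) in this assay, so at this carbonyl carbon the ring does not match the open chains. Cyclobutyl in place of hydroxymethyl gives a number 10.2 percentage points lower from compound 3 to compound 4 (beyond the scatter) and so the low numbers here are not confined to the group with the hydroxy. Nothing available explains these drops. From the compounds shown here alone, whether cyclopropyl, cyclopentyl or an aminomethyl group on this carbonyl carbon would sit with cyclobutyl or with the open chains remains open.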